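Glycine transporter series: oxanyl amide to pyridyl amide

This account rests on a few compounds, and the source may have more. Where it says the series, first, only, none or still open, it means among the compounds named here.

compound 1 `O=C(CN(C(=O)c1ccc(Cl)cc1)C1CCCCC1)Nc1cc(F)cc(F)c1`: 631 nM in an assay on HEK293 cells for inhibition of sodium- and chloride-dependent glycine transporter 1 (Homo sapiens), read by scintillation proximity assay; on this read-out lower numbers stand for stronger inhibition and higher numbers for weaker inhibition
compound 2 `O=C(CN(Cc1ccc(Cl)cc1)C1CCCCC1)Nc1cc(F)cc(F)c1`: compound 2 gives > 25100 nM in this assay, a limit of the assay rather than a number the limit of > 25100 nM in this assay, at which 1 of the 3 values shown sits.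
compound 3 `O=C(CN(C(=O)C1CCOCC1)C1CCCCC1)Nc1cc(F)cc(F)c1`: 5010 nM in this assay

For the measured compounds named here, compound 3 holds the highest of the two numbers; the only step between numbers is a 7.9-fold higher number from compound 1 to compound 3 (0.90 log units; beyond the scatter), the one where oxan-4-yl replaced 4-chlorophenyl on the carbonyl carbon. The step of an at least 39-fold higher number from compound 1 to compound 2 (1.59 log units; beyond the scatter) concerns the carbonyl itself and does not bear on a ring swap; an at least 5.0-fold lower number from compound 2 to compound 3 (0.69 log units; beyond the scatter) starts from a limit.

Compound 4 `O=C(CN(C(=O)c1cccnc1)C1CCCCC1)Nc1cc(F)cc(F)c1` is not yet measured. Its change is pyridin-3-yl in place of oxan-4-yl on a carbonyl carbon. An aromatic six-membered ring returns to the carbonyl carbon, so part of the loss seen in compound 3 relative to compound 1 is expected to be recovered, though the pyridyl ring is not the 4-chlorophenyl ring. The estimated step is a 2.5-fold lower number from compound 3 to compound 4 (0.40 log units; beyond the scatter). Compound 4 is expected near 2000 nM, between 700 nM and 6000 nM.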

Compound 4, half-maximal inhibitory concentration: > 25100 nM
Compound 4 ended at the assay's limit (the forecaster's own chance of this, stated with the estimate: 5%); middle value at least 12-fold (1.09 log units) from the limit.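

On the carbonyl carbon, an aromatic six-membered ring alone does not hold the activity: an at least 5.0-fold higher number from compound 3 to compound 4 (0.69 log units; beyond the scatter) comes with pyridin-3-yl in place of oxan-4-yl, so here the non-aromatic ring is the better of the two. an at least 39-fold higher number from compound 1 to compound 4 (1.59 log units; beyond the scatter) is the cost of pyridin-3-yl in place of 4-chlorophenyl. The value of compound 4 is a limit and not a number, and the step from compound 2 cannot be read: the limit of > 25100 nM in this assay, at which 2 of the 4 values shown sit.

Left open is whether the loss follows the ring nitrogen or the missing chlorine. A plain phenyl or a chloropyridinyl group on this carbonyl would separate the two.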